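The source may report more compounds than this note shows. Statements on the series, on what has been measured and on what is new or still open speak of the compounds shown alone.

In an ADME assay on the whole organism (strain Sprague-Dawley) for metabolic stability, with Rattus norvegicus as the target, read by LC-MS, at a dose of 50 mg/kg by the oral route (a higher number here means that the compound lasts longer, a lower number that the compound disappears faster), compound 1 `CCOC(=O)C1=C[C@@H](OC(CC)CC)[C@H](NC(C)=O)[C@@H](N/C(C)=N/O)C1` gives 1.85 h, compound 2 `CCOC(=O)C1=C[C@@H](OC(CC)CC)[C@H](NC(C)=O)[C@@H](N/C(N)=N\O)C1` gives 1.15 h and compound 3 `CCOC(=O)C1=C[C@@H](OC(CC)CC)[C@H](NC(C)=O)[C@@H](NC(C)=N)C1` gives 0.7 h. Two steps place compound 3 among these values: a 1.6-fold lower number from compound 2 to compound 3 (0.22 log units; within the scatter), and a 2.6-fold lower number from compound 1 to compound 3 (0.42 log units; beyond the scatter). The remaining measured step is a 1.6-fold lower number from compound 1 to compound 2 (0.21 log units; within the scatter).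

Compound 4 `CCOC(=O)C1=C[C@@H](OC(CC)CC)[C@H](NC(C)=O)[C@@H](NC(=N)N)C1` differs from compound 3 by amino in place of methyl on a carbon with a double bond to nitrogen. Among the measured compounds shown here, compounds 1 and 2 form the only measured pair with this same swap, so their step is the closest guide. It is a single pair, within the scatter, and shows no pattern. The other two measured steps involve a different change and bear on the question only by fixing the position of compound 3. A step beyond the scatter is therefore not expected, though the direction of the measured swap suggests a slightly lower number. The estimated step is a 1.4-fold lower number from compound 3 to compound 4 (0.15 log units; within the scatter). For compound 4 the expected half-life is 0.5 h, with an estimated range of 0.25 h to 1 h.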

Compound 4, half-life in the Rattus norvegicus assay: 1.45 h
The estimate for compound 4 lay 2.9-fold (0.46 log units) below the measured number; measured number outside the range, above it.
By their numbers in the Rattus norvegicus assay, from the lowest: compounds 3, 2, 4 and 1 (each within the scatter of the next, the first and the last beyond it).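

Among the compounds shown here, in the Rattus norvegicus assay, amino in place of methyl on a carbon with a double bond to nitrogen gives a 2.1-fold higher number from compound 3 to compound 4 (0.32 log units; beyond the scatter), the first reading of this swap beyond the scatter, whereas the only earlier pair with the same swap gave a 1.6-fold lower number from compound 1 to compound 2 (0.21 log units; within the scatter). Also in the Rattus norvegicus assay, both a 1.3-fold higher number from compound 2 to compound 4 (0.10 log units; within the scatter) and a 1.3-fold lower number from compound 1 to compound 4 (0.11 log units; within the scatter) lie within the scatter, so these steps do not separate the three compounds involved. In a physicochemical assay for solubility, read by HPLC, in phosphate buffer, with a stated time of 20 min, at pH 7.4 (a higher number here means a more soluble compound, a lower number a less soluble compound), compound 3 gives > 50000000 nM, which is a limit of the assay and not a number. In the physicochemical assay, compound 4 gives > 50000000 nM, which is also a limit of the assay. In the physicochemical assay, the step for this swap cannot be read because both compounds sit at an assay limit: the limit of > 50000000 nM in the physicochemical assay, at which 2 of the 2 values shown sit.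

As far as these compounds go, the result rests on one modest step, so it remains open whether ethyl or methylamino on this carbon would read like methyl or like amino. Also open, from the compounds shown here alone, is whether the swap would give a step beyond the scatter on a core carrying a different ether chain.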